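A few compounds are considered here, and "the series" means these few. Any claim that something is new, unique, unknown or untested is made for them only; others in the source may bear on it.

Working notes on the series.

Compound 1 `O=C(/C=C/c1ccc([N+](=O)[O-])o1)c1ccc(Br)cc1` is the reference of the set. In a functional assay on C6 cells (Rattus norvegicus) for inhibition, read by sulforhodamine B assay, with a stated time of 72 h (on this read-out lower numbers stand for an effect already at smaller amounts and higher numbers for an effect only at larger amounts of compound), compound 1 gives 2700 nM, the lowest number among the three measured compounds. Compound 2 `CC(C)(C)c1ccc(C(=O)/C=C/c2ccc([N+](=O)[O-])o2)cc1` gives 28600 nM and compound 3 `O=C(/C=C/c1ccc([N+](=O)[O-])o1)c1ccc(N2CCCC2)cc1` gives 16400 nM, so both sit well behind compound 1.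

Compound 4 `O=C(/C=C/c1ccc([N+](=O)[O-])o1)c1ccc(N2CCCCC2)cc1` is not yet measured. Its change from compound 1 is piperidin-1-yl in place of bromo on an aromatic carbon.

Among the compounds with values here, two measured steps bear on this change, both replacing bromo at the same aromatic carbon with a larger group: an 11-fold higher number from compound 1 to compound 2 (1.03 log units; beyond the scatter) and a 6.1-fold higher number from compound 1 to compound 3 (0.78 log units; beyond the scatter). Between the two larger groups the gap is small, a 1.7-fold lower number from compound 2 to compound 3 (0.24 log units; within the scatter), so the pattern across these three compounds is that moving away from bromo at this position costs a substantial amount, with little dependence on which larger group enters. Piperidin-1-yl is the nearest analogue of pyrrolidin-1-yl in the set, differing by one ring carbon, so compound 3 is the closest guide.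

For compound 4 in this assay a step of a 7.4-fold higher number from compound 1 to compound 4 (0.87 log units; beyond the scatter) is therefore expected, in the direction of a higher number. Compound 4 is estimated at 20000 nM, with a range of 8000 nM to 50000 nM.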

Compound 4, half-maximal effective concentration: 48700 nM
The estimate for compound 4 lay 2.4-fold (0.39 log units) below the measured number; measured number inside the range.
By their numbers in this assay, from the lowest: compound 1; then compounds 3, 2 and 4 (each within the scatter of the next, the first and the last beyond it).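

In this assay, piperidin-1-yl at this position confirms the cost of leaving bromo, with an 18-fold higher number from compound 1 to compound 4 (1.26 log units; beyond the scatter), so all three replacements shown now stand beyond the scatter from compound 1, and none goes against that. The identity of the entering group is no longer indifferent: a 3.0-fold higher number from compound 3 to compound 4 (0.47 log units; beyond the scatter) shows that even the exchange of pyrrolidin-1-yl for piperidin-1-yl moves the number beyond the scatter, while a 1.7-fold higher number from compound 2 to compound 4 (0.23 log units; within the scatter) leaves piperidin-1-yl and tert-butyl with no order between them. Nothing available on the series explains these differences.

The compounds shown leave open whether the lower number of compound 1 is particular to bromo or is shared by other groups at this position, such as chloro, fluoro or methoxy. Also open, as far as these compounds go, is how the amine series responds to a change in the ring or its removal, as with morpholin-4-yl or the open-chain dimethylamino group, which would test whether the step from pyrrolidin-1-yl to piperidin-1-yl belongs to a wider trend.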